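From 4-Cyanophenyl to 4-Methoxyphenyl: An Unmeasured Step

The source may hold more compounds than are shown below. What is called first, only, known or untested is meant among the compounds shown, and "the series" means these compounds.

In a functional assay on K562 cells (Homo sapiens) for antiproliferative activity, read by CCK-8 assay, with a stated time of 72 h (on this read-out lower numbers stand for stronger inhibition and higher numbers for weaker inhibition), compound 1 `Cc1cc(Nc2cc(N3CCN(C)CC3)nc(Nc3cccc([N+](=O)[O-])c3)n2)n[nH]1` gives 138 nM while compound 2 `Cc1cc(Nc2cc(N3CCN(C)CC3)nc(Nc3ccc(C#N)cc3)n2)n[nH]1` holds the lower of the two numbers at 58.1 nM and serves as the reference. Compound 3 `COc1ccc(Nc2nc(Nc3cc(C)[nH]n3)cc(N3CCN(C)CC3)n2)cc1` differs from compound 2 by methoxy in place of cyano on an aromatic carbon para to a large group. Within the data shown here, only one measured step bears on this, the modest 2.4-fold lower number from compound 1 to compound 2 (0.38 log units; beyond the scatter) on replacing 3-nitrophenyl with 4-cyanophenyl, and no methoxy compound has been measured. On that limited evidence, a modest step toward a higher number is expected in this assay here. Compound 3 is estimated at 120 nM with an expected range of 40 nM to 350 nM in this read-out.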

Compound 3, half-maximal inhibitory concentration: 271 nM
The estimate for compound 3 lay 2.3-fold (0.35 log units) below the measured number; measured number inside the range.
By their numbers in this assay, from the lowest: compound 2; then compounds 1 and 3 (each within the scatter of the next).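

In this assay, the para substituent on this aromatic ring clearly matters: methoxy in place of cyano gives a 4.7-fold higher number from compound 2 to compound 3 (0.67 log units; beyond the scatter) and removes the advantage of the 4-cyanophenyl group. The 4-methoxyphenyl and 3-nitrophenyl groups are not separated, with a 2.0-fold higher number from compound 1 to compound 3 (0.29 log units; within the scatter), so among these three compounds only compound 2 stands apart. Nothing available accounts for this difference. From the compounds shown here alone, whether an amine, a carboxamide or a chlorine atom on this same carbon would fall nearer compound 2 or compound 3 remains open.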